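Aminophenyl in place of hydroxyphenyl: expected cytotoxicity

The source may report more compounds than this note shows. Statements on the series, on what has been measured and on what is new or still open speak of the compounds shown alone.

Compound 1 `CC(/C=N/Nc1ccc([N+](=O)[O-])cc1)=N\NC(=O)c1ccccc1Cl` in an ADME assay on J774 cells (Mus musculus, strain BALB/c) for cytotoxicity, read by resazurin assay, with a stated time of 72 h; a lower number here means that less compound is tolerated, a higher number that more compound is tolerated: > 100000 nM, which is a limit of the assay.
Compound 2 `CC(/C=N/Nc1ccc([N+](=O)[O-])cc1)=N\NC(=O)c1ccccc1` in this assay: > 100000 nM, again a limit of the assay.
Compound 3 `CC(/C=N/Nc1ccc([N+](=O)[O-])cc1)=N\NC(=O)c1ccccc1O` in this assay: 29500 nM.

For the measured compounds named here, compound 3 thus holds the only actual number in the set; the other two values sit at the limit of > 100000 nM in this assay, at which 2 of the 3 values shown sit. Two measured steps lead into compound 3. The step of an at least 3.3-fold lower number from compound 1 to compound 3 (0.53 log units; beyond the scatter) and the step of an at least 3.3-fold lower number from compound 2 to compound 3 (0.53 log units; beyond the scatter) both show that placing a hydroxy group on the aromatic carbon brings the number down from the limit to a readable value. The step that the two limits leave unreadable from compound 1 to compound 2 cannot be read, since both ends are limits.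

Compound 4 `CC(/C=N/Nc1ccc([N+](=O)[O-])cc1)=N\NC(=O)c1ccc(N)cc1` differs from compound 3 by 4-aminophenyl in place of 2-hydroxyphenyl on a carbonyl carbon. Going by the values given here, the hydroxy group that accompanied the lower number in compound 3 is gone, and an amino group appears on the same ring at a different position; no measured compound carries an amino group there, so its effect is not known from these data. What the two readable steps suggest is that taking away the hydroxy group moves the number back toward the limit. Compound 4 is therefore expected to give a higher number, around 70000 nM, within 25000 nM to 200000 nM, with a good chance that only a limit is reported. This corresponds to an expected step of a 2.4-fold higher number from compound 3 to compound 4 (0.38 log units; beyond the scatter).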

Compound 4, half-maximal cytotoxic concentration: 75000 nM
Beside the measured number, compound 4's estimate is 1.1-fold (0.03 log units) below it, and the stated range covers the measured number.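

Replacing 2-hydroxyphenyl with 4-aminophenyl on this carbonyl carbon gives a 2.5-fold higher number from compound 3 to compound 4 (0.41 log units; beyond the scatter) in this assay, so this position tolerates a change of ring substituent and the number shifts only modestly. For the compounds shown here, compound 4 also adds the first amino group to the set, yet its effect stays faint: the amino group in place of hydrogen gives an at least 1.3-fold lower number from compound 2 to compound 4 (0.12 log units; that floor lies within the scatter), and 4-aminophenyl in place of 2-chlorophenyl gives an at least 1.3-fold lower number from compound 1 to compound 4 (0.12 log units; that floor lies within the scatter), and neither floor clears the scatter. These two steps have no upper end, and an amino group cannot be said to lower the number as the hydroxy group did, because compounds 1 and 2 give only limits: the limit of > 100000 nM in this assay, at which 2 of the 4 values shown sit.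

The names 2-hydroxyphenyl and 4-aminophenyl differ both in the group and in where it sits on the ring, and the compounds shown cannot separate those two changes. On these data alone, how a methoxy group or a carboxylic acid on this ring would behave, and whether a true number for compounds 1 and 2 would make the amino step larger, also remain open.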